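Formyl on the cyclopropylamino nitrogen of compound 1

The source may hold more compounds than are shown below. What is called first, only, known or untested is meant among the compounds shown, and "the series" means these compounds.

Compound 1 `c1nc(NC2CC2)c2ncn(CC3CCC3)c2n1` has been measured in a functional assay on the whole organism for antagonist activity, with Rattus norvegicus as the target (on this read-out higher numbers stand for an effect only at larger amounts of compound and lower numbers for an effect already at smaller amounts), and gives 10 mg/kg. Of the two compounds with a single number it has the lower one; the nearest is compound 3 `CCC(C)n1cnc2c(NC3CC3)ncnc21`, which in this assay gives 13.5 mg/kg, the step between them reading a 1.4-fold higher number from compound 1 to compound 3 (0.13 log units; within the scatter). Compound 2 `CC(C1CC1)n1cnc2c(NC3CC3)ncnc21` carries several entries in this assay, 2 mg/kg; 4.5 mg/kg; 12.5 mg/kg (3 entries); their spread the several entries of compound 2 in this assay, 2 mg/kg; 4.5 mg/kg; 12.5 mg/kg (3 entries) shows how far repeated runs of this read-out can lie apart. Compound 4 `O=CN(c1ncnc2c1ncn2CC1CCC1)C1CC1` differs from compound 1 in one place: formyl in place of hydrogen on a nitrogen on an aromatic ring. Among the measured compounds shown here, no measured step touches this amino nitrogen; the only measured step exchanges the group on the aromatic ring nitrogen and stays within the scatter, so it gives no direction for the present change. For the measured compounds named here, with no precedent either way, compound 4 is expected to stay close to compound 1, the expected step being a 1.4-fold higher number from compound 1 to compound 4 (0.15 log units; within the scatter). Compound 4 is therefore estimated at 14 mg/kg in this assay, with a range from 5 mg/kg to 45 mg/kg.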

Compound 4, dose for half-maximal effect: 7 mg/kg
Beside the measured number, compound 4's estimate is 2.0-fold (0.30 log units) above it; the measured number falls inside the stated range.
By their numbers in this assay, from the lowest: compounds 4, 1 and 3 (each within the scatter of the next).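

Formyl in place of hydrogen on the cyclopropylamino nitrogen gives, in this assay, a 1.4-fold lower number from compound 1 to compound 4 (0.15 log units; within the scatter), and this is the only step shown that touches this nitrogen. The number for compound 4 therefore stays level with that of compound 1 without the hydrogen on this nitrogen, so this position accepts a formyl group in this assay. The step is also small next to the distance between repeated runs of one compound: the several entries of compound 2 in this assay, 2 mg/kg; 4.5 mg/kg; 12.5 mg/kg (3 entries)

From the compounds shown here alone, whether this nitrogen accepts other groups stays open, such as methyl, acetyl or a longer acyl chain. Also open, going by these compounds, is whether formyl on this nitrogen reads the same with sec-butyl on the aromatic nitrogen, as in compound 3, in place of the cyclobutylmethyl of compound 1.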